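This account rests on a few compounds, and the source may have more. Where it says the series, first, only, none or still open, it means among the compounds named here.

Compound 1 `NC1=NC2(CCOCC2)N(OCCCOc2ccccc2)C(N)=N1` gives 86.1 nM in an assay on isolated protein for inhibition of Dihydrofolate reductase (Homo sapiens), read by spectrophotometry, using NADPH, with stated times of 5 s and 6 min; a higher number here means a weaker inhibitor, a lower number a stronger inhibitor. Going by these compounds, compound 2 `NC1=NC2(CCSCC2)N(OCCCOc2cccc(Cl)c2)C(N)=N1` has "not determined" (no result reported) in this assay, so its standing on this measure is unknown. Compound 3 `NC1=NC2(CCSCC2)N(OCCCOc2ccc(Cl)cc2)C(N)=N1` differs from compound 2 by 4-chlorophenyl in place of 3-chlorophenyl on an oxygen on a saturated carbon. Among the measured compounds shown here, no measured pair shows the effect of such a change here, so only a modest shift in this assay is expected, in either direction, and possibly none beyond the usual scatter. The expectation rests on compound 1, whose value of 86.1 nM is the single anchor. Compound 3 is therefore estimated at 70 nM, likely between 20 nM and 250 nM.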

Compound 3, half-maximal inhibitory concentration: 18.3 nM
Compound 3: middle estimate off by 3.8-fold (0.58 log units), on the high side; the whole stated range lies above it.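

In this assay, among the compounds shown here, compound 2 gives "not determined" (no result reported) and compound 3 gives 18.3 nM, so no step between them can be read. Going by these compounds, the effect of 4-chlorophenyl in place of 3-chlorophenyl on inhibition remains open. No evidence bears on this result.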